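Chloro in place of trifluoromethyl on the urea aryl ring

The source may hold more compounds than are shown below. What is called first, only, known or untested is meant among the compounds shown, and "the series" means these compounds.

Compound 2 `COc1cc(Cl)cc(-c2nn(-c3cccc(NC(=O)Nc4ccc(Cl)c(C(F)(F)F)c4)c3)cc2-c2ccncc2)c1` stands as the lower of the two numbers in a functional assay on HT-29 cells (Homo sapiens) for inhibition, read by sulforhodamine B assay, with a stated time of 48 h, tested at 1 uM (a lower number here means a stronger effect, a higher number a weaker effect of the compound at the concentration tested), where compound 2 gives 55%, while compound 1 `O=C(Nc1cccc(-n2cc(-c3ccncc3)c(-c3cc(O)cc(Cl)c3)n2)c1)Nc1ccc(Cl)c(Cl)c1` gives 96%, a gap beyond the scatter. Compound 3 `COc1cc(Cl)cc(-c2nn(-c3cccc(NC(=O)Nc4ccc(Cl)c(Cl)c4)c3)cc2-c2ccncc2)c1` carries chloro in place of trifluoromethyl on an aromatic carbon. Among the compounds with values here, no step between measured compounds speaks to this change, so only a modest step from compound 2 to compound 3 in this assay is expected, toward a somewhat higher number, a number 10 percentage points higher from compound 2 to compound 3 (within the scatter). Compound 3 is therefore estimated at 65%, within 42% to 90%.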

Compound 3, a percentage reported as activity, at one concentration (the size of the read-out at that concentration, not a potency): 62%
Estimate against measurement, compound 3: 3 percentage points above, and the stated range covers the measured number.
By their numbers in this assay, from the lowest: compounds 2 and 3 (each within the scatter of the next); then compound 1.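

In this assay the change from 4-chloro-3-(trifluoromethyl)phenyl to 3,4-dichlorophenyl does not separate the two compounds (a number 7 percentage points higher from compound 2 to compound 3 (within the scatter)), so chloro and trifluoromethyl read alike at this place on this background. Within the data shown here, with 3,4-dichlorophenyl held constant, methyl in place of hydrogen on an oxygen on an aromatic ring gives a large step (a number 34 percentage points lower from compound 1 to compound 3 (beyond the scatter)), the first single-place comparison to do so. Nothing available explains either step.

As far as these compounds go, how a bromo group or a nitrile at this place would read remains open, as does an ethyl group on that oxygen.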